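The source may hold more compounds than are shown below. What is called first, only, known or untested is meant among the compounds shown, and "the series" means these compounds.

Four nucleoside analogues share one core and differ at two positions. Among the measured compounds shown here, compound 2 `COc1ncnc2c1c(-c1cccs1)cn2[C@@H]1O[C@H](CO)[C@@H](O)[C@H]1O` is the only one with a plain number: in a functional assay on HL-60 cells (Homo sapiens) for antiproliferative activity, read by XTT assay, with a stated time of 72 h (on this read-out lower numbers stand for stronger inhibition and higher numbers for weaker inhibition), compound 2 gives 80 nM. Compound 3 `COc1nc(N)nc2c1c(-c1cccs1)cn2[C@@H]1O[C@H](CO)[C@@H](O)[C@H]1O` is the amino-bearing partner, so that compound 2 arises from compound 3 by hydrogen in place of amino on an aromatic carbon. In this assay compound 3 reaches only a limit of the assay, > 20000 nM. The step of an at least 250-fold higher number from compound 2 to compound 3 (2.39 log units; beyond the scatter) therefore runs up to the limit of > 20000 nM in this assay, at which 2 of the 3 values shown sit. Compound 1 `COc1nc(N)nc2c1c(-c1ccccc1)cn2[C@@H]1O[C@H](CO)[C@@H](O)[C@H]1O` keeps the amino group and carries the change (phenyl in place of thiophen-2-yl on an aromatic carbon). In this assay compound 1 also gives only a limit, > 20000 nM. The step that the two limits leave unreadable from compound 3 to compound 1 hence cannot be sized from these two values. Compound 4 `COc1ncnc2c1c(-c1ccccc1)cn2[C@@H]1O[C@H](CO)[C@@H](O)[C@H]1O` has not yet been measured in this assay; it differs from compound 2 by phenyl in place of thiophen-2-yl on an aromatic carbon, the same change as from compound 3 to compound 1. The expectation for compound 4 rests on compound 2 with its 80 nM, since the other occurrence of the change is unreadable, and a modest step of a 1.9-fold higher number from compound 2 to compound 4 (0.27 log units; within the scatter) is expected. Compound 4 is thus estimated at 150 nM in this assay, within 40 nM to 800 nM.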

Compound 4, half-maximal inhibitory concentration: > 20000 nM
Compound 4 was reported as a limit; the forecaster's own chance of this, stated with the estimate: 10%; at least 130-fold (2.12 log units) between middle value and limit.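

In this assay, phenyl in place of thiophen-2-yl on the core without the amino group gives an at least 250-fold higher number from compound 2 to compound 4 (2.39 log units; beyond the scatter), so on this core the change is large and beyond the scatter. On the amino-bearing core the same change cannot be read, and neither can the step from compound 1 to compound 4, as both ends of each are limits, so the compounds do not show whether the effect of the change carries from one core to the other. The large step is itself bounded by a limit, and most of the set sits there: the limit of > 20000 nM in this assay, at which 3 of the 4 values shown sit.

The compounds shown leave open whether a furan-2-yl or thiophen-3-yl group on this aromatic carbon would stay close to compound 2 at 80 nM. Also open, as far as these compounds go, is whether methyl or a chlorine atom in place of the amino group of compound 3 would give a plain number in this assay.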